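Replacing the 1,3-benzoxazol-2-yl group of compound 2

A few compounds are considered here, and "the series" means these few. Any claim that something is new, unique, unknown or untested is made for them only; others in the source may bear on it.

For the measured compounds named here, in a functional assay on cells (Homo sapiens) for antiproliferative activity, read by MTT assay, with a stated time of 48 h (a lower number here means a stronger inhibitor, a higher number a weaker inhibitor), only two compounds have numbers so far. Compound 1 `N#Cc1nc2c(-c3nc4ccccc4o3)c(N)n(CCCN3CCCCC3)c2nc1C#N` gives 32200 nM, and compound 2 `CCN(CC)CCCCn1c(N)c(-c2nc3ccccc3o2)c2nc(C#N)c(C#N)nc21` gives 2710 nM, the lower of the two. Going by the values given here, the one measured step, a 12-fold lower number from compound 1 to compound 2 (1.07 log units; beyond the scatter), is large and beyond the scatter. It concerns only the chain, with (diethylamino)methyl in place of piperidin-1-yl, and leaves the 1,3-benzoxazol-2-yl group unchanged.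

Compound 3 `CCN(CC)CCCCn1c(N)c(-c2nc3ccccc3n2C)c2nc(C#N)c(C#N)nc21` keeps the 4-(diethylamino)butyl group of compound 2. The change is 1-methyl-1H-benzimidazol-2-yl in place of 1,3-benzoxazol-2-yl on an aromatic carbon, next to the ring atom that bears an amino group.

Among the compounds with values here, no measured step touches this place, so the chain step gives neither a size nor a direction for it. Without such evidence, no shift beyond the scatter is expected in this assay, and the range is kept wide. The expected change is a 1.1-fold higher number from compound 2 to compound 3 (0.04 log units; within the scatter). For compound 3 the estimated value is 3000 nM, with an expected range of 900 nM to 10000 nM.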

Compound 3, half-maximal inhibitory concentration: 2890 nM
Compound 3: middle estimate off by 1.0-fold (0.02 log units), on the high side; low and high end bracket the measured number.
By their numbers in this assay, from the lowest: compounds 2 and 3 (each within the scatter of the next); then compound 1.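

In this assay, for the compounds shown here, the first step at this position, a 1.1-fold higher number from compound 2 to compound 3 (0.03 log units; within the scatter), lies within the scatter. With the 4-(diethylamino)butyl group held, 1-methyl-1H-benzimidazol-2-yl therefore stands in for 1,3-benzoxazol-2-yl on this aromatic carbon without a measurable shift, although the entering group carries nitrogen and a methyl group where the leaving group carries oxygen, and the hydrogen-bond donor and acceptor counts of the two groups are equal. Among the steps shown, only the chain step, a 12-fold lower number from compound 1 to compound 2 (1.07 log units; beyond the scatter), lies beyond the scatter, and no information is available to explain why this exchange at the aromatic carbon leaves the number within the scatter.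

The compounds shown leave open whether this tolerance extends to groups further from these two, such as an unsubstituted 1H-benzimidazol-2-yl, a 1-ethyl-1H-benzimidazol-2-yl or a simple phenyl ring at the same carbon. They also leave open whether the exchange would give a similar result with the piperidin-1-yl chain of compound 1, since both compounds of the new step carry the 4-(diethylamino)butyl group.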